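Compound 3: 3-Methylthiophen-2-yl in Place of 4-Methylphenyl

The source may report more compounds than this note shows. Statements on the series, on what has been measured and on what is new or still open speak of the compounds shown alone.

Measured compounds:
Compound 1 `Cc1ccc(-c2nc(CNc3ccc(C(=O)NO)cc3)n(-c3ccccc3)n2)cc1` gives 224 nM
Compound 2 `O=C(NO)c1ccc(NCc2nc(-c3ccc(F)cc3)nn2-c2ccccc2)cc1` gives 115 nM

In an assay on Sf9 cells for inhibition of protein deacetylase HDAC6 (Homo sapiens), read by fluorescence, with a stated time of 40 min (a lower number here means a stronger inhibitor, a higher number a weaker inhibitor), compound 1 gives 224 nM, the higher of the two numbers shown, while compound 2 gives 115 nM; the step of a 1.9-fold lower number from compound 1 to compound 2 (0.29 log units; within the scatter) lies within the scatter, so the two compounds are not set apart. Compound 3 `Cc1ccsc1-c1nc(CNc2ccc(C(=O)NO)cc2)n(-c2ccccc2)n1` has not yet been measured. It differs from compound 1 in one place: 3-methylthiophen-2-yl in place of 4-methylphenyl on an aromatic carbon. Among the measured compounds shown here, no measured step touches this exchange; the only step at hand, a 1.9-fold lower number from compound 1 to compound 2 (0.29 log units; within the scatter), concerns a different substituent on the same 4-methylphenyl group and is itself within the scatter. With nothing to push the number either way, compound 3 is expected to stay close to compound 1, and a 1.1-fold lower number from compound 1 to compound 3 (0.05 log units; within the scatter) is anticipated to remain within the scatter. Compound 3 is therefore estimated at 200 nM, with a range from 70 nM to 600 nM.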

Compound 3, half-maximal inhibitory concentration: 30.7 nM
Beside the measured number, compound 3's estimate is 6.5-fold (0.81 log units) above it, and the stated range ends above it.
By their numbers in this assay, from the lowest: compound 3; then compounds 2 and 1 (each within the scatter of the next).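

In this assay, the group on this aromatic carbon, which lies between two ring nitrogen atoms, proves able to move the number beyond the scatter. Placing 3-methylthiophen-2-yl in place of 4-methylphenyl gives a 7.3-fold lower number from compound 1 to compound 3 (0.86 log units; beyond the scatter), whereas the earlier exchange of fluoro for methyl on the six-membered ring had stayed within the scatter. The same group also stands apart from 4-fluorophenyl, with a 3.7-fold lower number from compound 2 to compound 3 (0.57 log units; beyond the scatter), and no measurement at hand speaks to why the number falls in either step.

The compounds shown leave open whether the five-membered sulfur ring or the methyl group on it carries these steps, a question that unsubstituted thiophen-2-yl would address. From the compounds shown here alone, it also remains open whether 3-chlorothiophen-2-yl or 3-ethylthiophen-2-yl would hold the lower number.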